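Adding a Second Chlorine to a Purine-like Growth Inhibitor

The source may report more compounds than this note shows. Statements on the series, on what has been measured and on what is new or still open speak of the compounds shown alone.

This short series concerns a fused two-ring core carrying a chloro group, joined through a benzylic linker to a second aromatic ring that bears a chloromethyl group. Compound 1 `ClCc1ccccc1Cn1cnc2c(Cl)ncnc21` has the linker attached at one position of that outer ring and, in a functional assay on HCT-116 cells (Homo sapiens) for cytotoxicity, read by sulforhodamine B assay, with a stated time of 48 h (on this read-out lower numbers stand for stronger inhibition of growth and higher numbers for weaker inhibition of growth), compound 1 gives 1900 nM. Compound 2 `ClCc1ccc(Cn2cnc3ncnc(Cl)c32)cc1` moves the linker to another position on the outer ring; in this assay compound 2 is recorded as "not determined" (no result reported), so compound 2 stands without a number of its own, and the only measured point in the series is compound 1.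

Compound 3 `ClCc1ccc(Cn2cnc3nc(Cl)nc(Cl)c32)cc1` differs from compound 2 in one place: chloro in place of hydrogen on an aromatic carbon. Going by the values given here, without a measured value for compound 2, no step between measured compounds can be drawn, and the size and direction of the change from compound 2 to compound 3 in this assay cannot be anchored; any shift within the usual scatter would be unsurprising. Taking compound 1 as the only reference, the concentration for compound 3 in this assay is expected to be around 1500 nM, with a plausible range from 400 nM to 6000 nM.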

Compound 3, concentration for 50% growth inhibition: 120 nM
Estimate against measurement, compound 3: 13-fold (1.10 log units) above; measured number outside the range, below it.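

In this assay, going by these compounds alone, compound 3 gives 120 nM, but compound 2 has no number to set against it, so no step between these two compounds can be read. On these data alone, what the added chloro group does to growth inhibition therefore stays open. Nothing shown here offers an explanation for the value of compound 3.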